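A few compounds are considered here, and "the series" means these few. Any claim that something is new, unique, unknown or untested is made for them only; others in the source may bear on it.

Measured compounds:
Compound 1, `CC(=O)N1N=C(c2cccc3ccccc23)CC1c1ccccc1`, gives 8460 nM in a functional assay on PC-3 cells (Homo sapiens) for cytotoxicity, read by sulforhodamine B assay, with a stated time of 48 h; on this read-out higher numbers stand for weaker inhibition and lower numbers for stronger inhibition.
Compound 2, `CC(=O)N1N=C(c2cccc3ccccc23)CC1c1ccco1`, gives 18000 nM in this assay.

Going by the values given here, of these two numbers compound 2 holds the higher one, so it is the weaker inhibitor of the pair; its only neighbour is compound 1, and the step between them, a 2.1-fold higher number from compound 1 to compound 2 (0.33 log units; beyond the scatter), is modest yet beyond the scatter.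

Compound 3, `COc1ccc(C2CC(c3cccc4ccccc34)=NN2C(C)=O)cc1`, is reached from compound 2 by a single change: 4-methoxyphenyl in place of furan-2-yl on a saturated ring carbon. Among the compounds with values here, the one measured step that bears on this position is a 2.1-fold higher number from compound 1 to compound 2 (0.33 log units; beyond the scatter), where furan-2-yl in place of phenyl raised the number. Within the data shown here, compound 3 carries a six-membered carbon ring again, now bearing a methoxy group, which puts it closer to compound 1 than to compound 2 on the only comparison available. Among the measured compounds shown here, a return toward the level of compound 1 is therefore expected, while the methoxy group itself has no precedent here, so the range is kept wide. For compound 3 the expected step is a 2.0-fold lower number from compound 2 to compound 3 (0.30 log units; within the scatter). The estimate for compound 3 in this assay is 9000 nM, with a range from 3500 nM to 25000 nM.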

Compound 3, half-maximal inhibitory concentration: 4930 nM
Compound 3: the middle estimate sits 1.8-fold (0.26 log units) above what was measured; the range from low to high includes it.
By their numbers in this assay, from the lowest: compounds 3 and 1 (each within the scatter of the next); then compound 2.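

In this assay, the saturated ring carbon now carries three different groups, and the step of a 3.7-fold lower number from compound 2 to compound 3 (0.56 log units; beyond the scatter) shows that exchanging furan-2-yl for 4-methoxyphenyl moves the number beyond the scatter. The methoxy group itself makes no readable difference, since adding it to the phenyl group of compound 1 gives a 1.7-fold lower number from compound 1 to compound 3 (0.23 log units; within the scatter), so among these three compounds, the furan-2-yl group of compound 2 alone stands apart, while the phenyl and 4-methoxyphenyl groups cannot be told apart. No measurement here explains why the five-membered ring gives the higher number.

As far as these compounds go, these three compounds vary only the group on that saturated ring carbon, so it remains open whether an amine or a carboxylic acid in place of the methoxy group, or a longer chain such as butoxy, would move the number beyond the scatter. From the compounds shown here alone, it also remains open whether the same order of groups would hold with a longer chain in place of the acetyl group, or in cells other than the ones used here.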